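This account rests on a few compounds, and the source may have more. Where it says the series, first, only, none or still open, it means among the compounds named here.

Measured compounds:
Compound 1, `CC(C)(C)c1ccc(CNCCCNS(=O)(=O)c2cc(C(F)(F)F)cc(C(F)(F)F)c2)cc1`; in a functional assay on BXPC-3 cells (Homo sapiens) for inhibition, read by MTT assay, with a stated time of 72 h (on this read-out lower numbers stand for stronger inhibition of growth and higher numbers for weaker inhibition of growth), compound 1 gives 1400 nM.
Compound 2, `O=S(=O)(NCCNCc1ccc(-c2ccccc2)cc1)c1cc(C(F)(F)F)cc(C(F)(F)F)c1`; in this assay compound 2 gives 1600 nM.
Compound 3, `O=S(=O)(NCCCNCc1ccc(-c2ccccc2)cc1)c1cc(C(F)(F)F)cc(C(F)(F)F)c1`; in this assay compound 3 gives 1700 nM.

The three measured values lie close together, and none of the pairwise gaps goes beyond the usual scatter. Compound 4, `CC(C)(C)c1ccc(CNCCNS(=O)(=O)c2cc(C(F)(F)F)cc(C(F)(F)F)c2)cc1`, has not yet been measured. It differs from compound 2 by a single change: tert-butyl in place of phenyl on an aromatic carbon. The same change is already seen between two measured compounds, compound 3 and compound 1, where it is described as tert-butyl in place of phenyl on an aromatic carbon; the two place descriptions agree word for word, so this is the same change. Its effect there was a 1.2-fold lower number from compound 3 to compound 1 (0.08 log units; within the scatter), a step within the scatter. The cores of compound 2 and compound 3 differ in more than one place, and that difference is not broken down here.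

Resting on compound 2 with 1600 nM and on the step of a 1.2-fold lower number from compound 3 to compound 1 (0.08 log units; within the scatter), the expected step from compound 2 to compound 4 is a 1.2-fold lower number from compound 2 to compound 4 (0.07 log units; within the scatter). Compound 4 is therefore estimated at 1350 nM in this assay, with a likely range from 700 nM to 2700 nM.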

Compound 4, concentration for 50% growth inhibition: 8800 nM
Compound 4: middle estimate off by 6.5-fold (0.81 log units), on the low side, and the stated range ends below it.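

In this assay, tert-butyl in place of phenyl on an aromatic carbon gives a 5.5-fold higher number from compound 2 to compound 4 (0.74 log units; beyond the scatter), and this differs clearly from what the same change does on the other core: the same change on two cores in this assay, a 1.2-fold lower number (0.08 log units; within the scatter) from compound 3 to compound 1 and a 5.5-fold higher number (0.74 log units; beyond the scatter) from compound 2 to compound 4, 6.7-fold (0.82 log units) apart, beyond the scatter of two such steps Within these four compounds, then, the step does not carry over from one core to the other, and the step read on the core of compound 3 gave no reliable guide to the step on the core of compound 2. This shows only that the outcome of the change depends on the core in this one pair of pairs; it does not show which difference between the two cores is responsible, nor which of the two steps is the more usual one in the series.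

From the compounds shown here alone, it remains open how a third core would respond to the same change. Also open, going by these compounds, is whether other groups in the same place, such as isopropyl, cyclohexyl or methoxy, would follow compound 2 or compound 4 on this core.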